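The source may report more compounds than this note shows. Statements on the series, on what has been measured and on what is new or still open speak of the compounds shown alone.

For the measured compounds named here, in a functional assay on HeLa cells (Homo sapiens) for antiproliferative activity, with a stated time of 24 h (a lower number here means a stronger inhibitor, a higher number a weaker inhibitor), compound 2 `NC(=O)c1c(NC(=O)c2ccccc2C(F)(F)F)sc2c1CCN(C(=S)Nc1ccccc1Cl)C2` gives 46900 nM as the only true number so far. Compound 1 `NC(=O)c1c(NC(=O)c2ccccc2I)sc2c1CCN(C(=S)Nc1ccccc1Cl)C2` reads > 50000 nM which is a limit of the assay. Compound 3 `Cc1ccc(C(=O)Nc2sc3c(c2C(N)=O)CCN(C(=S)Nc2ccccc2Cl)C3)cc1` differs from compound 2 by 4-methylphenyl in place of 2-(trifluoromethyl)phenyl on a carbonyl carbon on the shared core, with 4-methylphenyl in place of 2-(trifluoromethyl)phenyl on a carbonyl carbon. Going by the values given here, the sole measured step an at least 1.0-fold lower number from compound 1 to compound 2 (0.02 log units; that floor lies within the scatter) lies within the scatter and changes a group on the same aromatic ring, so no shift beyond the scatter is expected in this assay and no direction is favoured. The expected size is a 1.2-fold lower number from compound 2 to compound 3 (0.07 log units; within the scatter) and stays within the scatter. Compound 3 is estimated at 40000 nM with 15000 nM to 60000 nM as its range.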

Compound 3, half-maximal inhibitory concentration: 26300 nM
For compound 3 the middle estimate is 1.5-fold (0.18 log units) above the measured one; the range from low to high includes it.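

In this assay, replacing the aryl group on the carbonyl carbon, not just a substituent on the same ring position, still gives no shift beyond the scatter (a 1.8-fold lower number from compound 2 to compound 3 (0.25 log units; within the scatter)). The 4-methylphenyl group read against 2-iodophenyl also stays within the scatter on its floor (an at least 1.9-fold lower number from compound 1 to compound 3 (0.27 log units; that floor lies within the scatter)). As far as these compounds go, compound 1 is a limit and not a number, so the true size of that step stays unknown: the limit of > 50000 nM in this assay, at which 1 of the 3 values shown sits.

Open, from the compounds shown here alone, is whether an amine or a carboxylic acid on this phenyl ring, or a longer chain in its place, would move the number beyond the scatter.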